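Compound 3 to compound 4: phenyl to pent-4-en-1-yl

The source may report more compounds than this note shows. Statements on the series, on what has been measured and on what is new or still open speak of the compounds shown alone.

In an ADME assay on HII4E cells (Mus musculus) for cytotoxicity, read by MTT assay, with a stated time of 48 h (on this read-out higher numbers stand for weaker inhibition and lower numbers for stronger inhibition), compound 3 (`O=C(CO[C@H]1O[C@H](CO)[C@H](O)[C@H](O)[C@H]1O)NCc1cn(Cc2ccccc2)nn1`) gives 617 ug/mL, the highest of the three measured numbers and beyond the scatter from both others. Compound 1 (`CC(=O)OC[C@@H]1C=C(OC(C)=O)C(=O)[C@@H](OCC(=O)NCc2ccccc2)O1`) gives 163 ug/mL, and compound 2 (`CCCCCCCCCCCCNC(=O)CO[C@@H]1O[C@H](COC(C)=O)C=C(OC(C)=O)C1=O`) gives 45 ug/mL, the lowest number.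

Compound 4 (`C=CCCCCn1cc(CNC(=O)CO[C@H]2O[C@H](CO)[C@H](O)[C@H](O)[C@H]2O)nn1`) carries pent-4-en-1-yl in place of phenyl on a saturated chain carbon bound to an aromatic nitrogen. For the measured compounds named here, no measured pair isolates this change, so the expectation is a judgement. No step beyond the scatter is expected in this assay, with a slight lean toward a lower number. The expected 1.4-fold lower number from compound 3 to compound 4 (0.14 log units; within the scatter) is small. For compound 4 the estimated value is 450 ug/mL, with an expected range of 200 ug/mL to 900 ug/mL.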

Compound 4, half-maximal inhibitory concentration: 394 ug/mL
Estimate against measurement, compound 4: 1.1-fold (0.06 log units) above; the measured number falls inside the stated range.
By their numbers in this assay, from the lowest: compound 2; then compound 1; then compounds 4 and 3 (each within the scatter of the next).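

In this assay, the step at this position, a saturated chain carbon bound to an aromatic nitrogen, is a 1.6-fold lower number from compound 3 to compound 4 (0.19 log units; within the scatter), with pent-4-en-1-yl in place of phenyl. In this pair, the aromatic ring can therefore give way to an open chain with one double bond without a step beyond the scatter. Nothing measured here gives a cause for this result.

As far as these compounds go, whether a saturated pentyl chain, a terminal amine or a carboxylic acid on this carbon would also stay within the scatter of compound 3 remains open. Whether the same change behaves alike on another core is also unresolved.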